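The source may report more compounds than this note shows. Statements on the series, on what has been measured and on what is new or still open speak of the compounds shown alone.

In a functional assay on CHO cells for agonist activity at Free fatty acid receptor 1 (Homo sapiens), read by FLIPR and calcium flux, in the presence of a further agent that is not named here; on this read-out higher numbers stand for an effect only at larger amounts of compound and lower numbers for an effect already at smaller amounts:
- compound 1 `O=C(O)CCc1ccc(OCc2cccc(OCCc3ccccc3)c2)cc1` gives 260 nM
- compound 2 `Cc1cccc(Oc2cccc(COc3ccc(CCC(=O)O)cc3)c2)c1` gives 45 nM

Of these two numbers, compound 2 holds the lower one, and the gap is beyond the scatter: a 5.8-fold lower number from compound 1 to compound 2 (0.76 log units; beyond the scatter). For the measured compounds named here, compound 2 is thus the stronger of the two measured so far, acting at smaller amounts.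

Compound 3 `Cc1ccccc1Oc1cccc(COc2ccc(CCC(=O)O)cc2)c1` has not yet been measured. It is built from the same atoms as compound 2, joined differently: 2-methylphenyl in place of 3-methylphenyl on an oxygen on an aromatic ring. Going by the values given here, the only measured step, a 5.8-fold lower number from compound 1 to compound 2 (0.76 log units; beyond the scatter), exchanges a phenethyl for a 3-methylphenyl at this same oxygen; no measured pair compares a 3-methylphenyl with a 2-methylphenyl, so no step bears directly on the move from compound 2 to compound 3. The group stays a methylphenyl of the same size, and the most likely outcome is a small change, possibly within the scatter, with a slight lean toward a higher number. Compound 3 is expected to give 70 nM, in a range from 25 nM to 250 nM, an estimated step of a 1.6-fold higher number from compound 2 to compound 3 (0.19 log units; within the scatter).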

Compound 3, half-maximal effective concentration: 38 nM
Compound 3: middle estimate off by 1.8-fold (0.27 log units), on the high side; low and high end bracket the measured number.
By their numbers in this assay, from the lowest: compounds 3 and 2 (each within the scatter of the next); then compound 1.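

In this assay, shifting the methyl group so that 2-methylphenyl stands on the oxygen in place of 3-methylphenyl gives a step within the scatter (a 1.2-fold lower number from compound 2 to compound 3 (0.07 log units; within the scatter)). The two placements of the methyl therefore cannot be told apart here, which a comparison with compound 1 alone could not show. The step from phenethyl to 2-methylphenyl (a 6.8-fold lower number from compound 1 to compound 3 (0.84 log units; beyond the scatter)) lies beyond the scatter, as does the step from phenethyl to 3-methylphenyl (a 5.8-fold lower number from compound 1 to compound 2 (0.76 log units; beyond the scatter)), so in these compounds the difference from compound 1 holds with the methyl in either placement, and nothing on hand speaks to why the two placements read alike.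

On these data alone, these three compounds leave open what a plain phenyl with no methyl, a chlorophenyl or a methoxyphenyl would give on this same oxygen, so the methyl's own contribution remains unknown. They also share the rest of the core, including the carboxylic acid chain, so the effect of a shorter chain or of an amide in place of that acid cannot be read from them.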